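The compounds below may be only part of what the source reports. "The series", "measured", "known", "first", "only" and "open" are said of these compounds alone.

For the measured compounds named here, in an ADME assay (liver) for metabolic stability, with Liver microsome (Rattus norvegicus) as the target, read by LC-MS, using microsomes, with a stated time of 30 min, tested at 4 uM (a higher number here means that more of the compound is left, a lower number that less of the compound is left), compound 1 (`COc1cccc(-c2nc3c(N4CCN(C)CC4)nc(C)nc3n2C2CCOCC2)c1`) gives 30%, and compound 2 (`Cc1nc(N2CCN(C)CC2)c2nc(-c3ccccc3C3CC3)n(C3CCOCC3)c2n1`) gives 67%, the higher of the two numbers so far. The next structure is compound 3 (`COc1ccc(-c2nc3c(N4CCN(C)CC4)nc(C)nc3n2C2CCOCC2)c(C)c1`), with 4-methoxy-2-methylphenyl in place of 2-cyclopropylphenyl on an aromatic carbon, next to the ring atom that bears an oxan-4-yl group: 4-methoxy-2-methylphenyl in place of 2-cyclopropylphenyl on an aromatic carbon. Going by the values given here, one measured step bears on this change: a number 37 percentage points higher from compound 1 to compound 2 (beyond the scatter), a large step beyond the scatter, with 2-cyclopropylphenyl replacing 3-methoxyphenyl at the same place. Compound 3 loses the 2-cyclopropylphenyl and has a methoxy-bearing phenyl, as compound 1 does, but no measurement isolates the added methyl. Among the compounds with values here, with a number 37 percentage points higher from compound 1 to compound 2 (beyond the scatter) as the only guide, a partial return towards compound 1 is expected. The expected change is a number 25 percentage points lower from compound 2 to compound 3 (beyond the scatter), a sizeable fall. In this assay the estimate for compound 3 is 42%, with an expected range of 25% to 62%.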

Compound 3, percent of the compound remaining: 24%
Beside the measured number, compound 3's estimate is 18 percentage points above it; the measured number lies below the stated range.
By their numbers in this assay, from the lowest: compounds 3 and 1 (each within the scatter of the next); then compound 2.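

In this assay, the change from 2-cyclopropylphenyl to 4-methoxy-2-methylphenyl at this aromatic carbon gives a number 43 percentage points lower from compound 2 to compound 3 (beyond the scatter), so the earlier rise does not carry over to every phenyl group with a substituent at its 2-position. The step from 3-methoxyphenyl to 4-methoxy-2-methylphenyl gives a number 6 percentage points lower from compound 1 to compound 3 (within the scatter), which leaves the two methoxy-bearing groups not separated in this assay. Among these three compounds, only the 2-cyclopropylphenyl of compound 2 stands apart, at 67%.

Nothing available explains these differences. On these data alone, it remains open whether the number of compound 2 follows the cyclopropyl group or the lack of a methoxy group, a question that 2-methylphenyl or 2-ethylphenyl at this place on the shared core would help to separate.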